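The source may report more compounds than this note shows. Statements on the series, on what has been measured and on what is new or still open speak of the compounds shown alone.

Measured compounds:

Compound 1, `Nc1cccc2c(-c3cccc(NC(=O)c4ccc(Cl)c(C(F)(F)F)c4)c3)ccnc12`: in a functional assay on UACC-62 cells (Homo sapiens) for antiproliferative activity, read by sulforhodamine B assay, with a stated time of 48 h (on this read-out higher numbers stand for weaker inhibition and lower numbers for stronger inhibition), compound 1 gives 2700 nM.
Compound 2, `CC(=O)Nc1cccc2c(-c3cccc(NC(=O)c4ccc(Cl)c(C(F)(F)F)c4)c3)ccnc12`: in this assay compound 2 gives 2400 nM.
Compound 3, `Nc1cccc2c(-c3cccc(NC(=O)Nc4cc(C(F)(F)F)cc(C(F)(F)F)c4)c3)ccnc12`: in this assay compound 3 gives 1800 nM.

Compound 1 and compound 2 share one core and differ in a single place: acetyl in place of hydrogen on a nitrogen on an aromatic ring. That change made a step of a 1.1-fold lower number from compound 1 to compound 2 (0.05 log units; within the scatter), so the two compounds cannot be told apart by this measurement. Compound 3 carries a different core; the difference between the two cores is not broken down here. Its value sits close to those of compound 1 and compound 2, and none of the three stands apart from the others beyond the usual scatter.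

Compound 4, `CC(=O)Nc1cccc2c(-c3cccc(NC(=O)Nc4cc(C(F)(F)F)cc(C(F)(F)F)c4)c3)ccnc12`, has not yet been measured. It stands to compound 3 exactly as compound 2 stands to compound 1: acetyl in place of hydrogen on a nitrogen on an aromatic ring. The place of the change is described in the same words in both pairs, so this is the same change made on the second core.

For the measured compounds named here, the only guide to what this change does is the pair already measured. Because the step of a 1.1-fold lower number from compound 1 to compound 2 (0.05 log units; within the scatter) was small, the expectation for compound 4 is a step of about a 1.1-fold lower number from compound 3 to compound 4 (0.02 log units; within the scatter) in this assay, which would leave compound 4 close to compound 3. Compound 4 is therefore estimated at 1700 nM, with a likely range from 800 nM to 3500 nM.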

Compound 4, half-maximal inhibitory concentration: 10600 nM
Estimate against measurement, compound 4: 6.2-fold (0.79 log units) below, outside the stated range (above it).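

In this assay, changing amino to acetamido on the core of compound 3 gave a 5.9-fold higher number from compound 3 to compound 4 (0.77 log units; beyond the scatter), so on this core the acetyl group goes with weaker inhibition, whereas on the core of compound 1 the same change left no readable difference. For the compounds shown here, the effect of this change therefore does not carry over unchanged from one core to the other, and a result on one core is a poor guide to the other: the same change on two cores in this assay, a 1.1-fold lower number (0.05 log units; within the scatter) from compound 1 to compound 2 and a 5.9-fold higher number (0.77 log units; beyond the scatter) from compound 3 to compound 4, 6.6-fold (0.82 log units) apart, beyond the scatter of two such steps This rests on only two matched pairs, so it shows that the core can matter but does not show which part of the core is responsible, why the two steps differ, or which of the two steps is more typical of the series.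

Going by these compounds, it remains open whether a longer chain on the carbonyl, such as propanoyl, or a simple methyl group on the same nitrogen would follow the acetyl step on the core of compound 3 or the one on the core of compound 1. A third core carrying the same amino and acetamido pair would also help to show whether the step seen with compound 4 is the exception or the more common outcome.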